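A few compounds are considered here, and "the series" means these few. Any claim that something is new, unique, unknown or untested is made for them only; others in the source may bear on it.

In a functional assay on MCF7 cells (Homo sapiens) for inhibition, read by MTT assay, with a stated time of 72 h (a lower number here means a stronger inhibitor, a higher number a weaker inhibitor), compound 1 (`C=C[C@]1(C)C[C@@H](OC(=O)CNC(=O)Nc2ccc(OC)cc2)[C@]2(C)[C@H](C)CC[C@]3(CCC(=O)[C@H]32)[C@@H](C)[C@@H]1O`) gives > 10000 nM, a limit of the assay and not a number. Compound 2 (`C=C[C@]1(C)C[C@@H](OC(=O)CNC(=O)Nc2ccc(Cl)cc2)[C@]2(C)[C@H](C)CC[C@]3(CCC(=O)[C@H]32)[C@@H](C)[C@@H]1O`) gives > 10000 nM, which is likewise only a limit. Compound 2 therefore stands at the limit of > 10000 nM in this assay, at which 2 of the 2 values shown sit, and no number fixes its position. Compound 3 (`C=C[C@]1(C)C[C@@H](OC(=O)CNC(=O)Nc2ccc(F)cc2)[C@]2(C)[C@H](C)CC[C@]3(CCC(=O)[C@H]32)[C@@H](C)[C@@H]1O`) keeps the shared core and differs from compound 2 at one place: fluoro in place of chloro on an aromatic carbon. The change lies on an aromatic carbon of a six-membered aromatic ring of carbon only, para to a large group. For the measured compounds named here, the one measured step bearing on it is a step that the two limits leave unreadable from compound 1 to compound 2, a change at the same place that gives no size to carry forward. In this assay the estimate is a step that the limit leaves unreadable from compound 2 to compound 3, and no shift beyond the scatter is expected. For compound 3 the expected value is 12000 nM, with an estimated range of 6000 nM to 30000 nM.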

Compound 3, half-maximal inhibitory concentration: > 10000 nM
Compound 3: no number, only a limit; the forecaster's own chance of this, stated with the estimate: 85%; the middle value does not contradict the limit.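

In this assay compound 3 gives > 10000 nM, a limit and not a number, so no step linking it to compound 1 or compound 2 can be read: the limit of > 10000 nM in this assay, at which 3 of the 3 values shown sit.

The compounds shown leave open whether methoxy, chloro and fluoro on that aromatic carbon differ at all in this assay.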